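The source may report more compounds than this note shows. Statements on the series, on what has been measured and on what is new or still open speak of the compounds shown alone.

Of the compounds shown here, three sharing one core have been measured in an assay for displacement of a labelled ligand from melanin-concentrating hormone receptor 1 (Homo sapiens), read by fluorescence; on this read-out lower numbers stand for stronger inhibition and higher numbers for weaker inhibition. Compound 1 `COc1ccccc1-c1nc2ccccc2n1CCCN1CCC(c2cccc(NC(C)=O)c2)CC1` gives 747 nM, the highest of the three numbers. Compound 2 `COc1ccc(-c2nc3ccccc3n2CCCN2CCC(c3cccc(NC(C)=O)c3)CC2)cc1` gives 9 nM in this assay, and compound 3 `CC(=O)Nc1cccc(C2CCN(CCCn3c(-c4ccc(Cl)cc4Cl)nc4ccccc43)CC2)c1` gives 3 nM. Exchanging the aryl group of compound 1 has so far produced only large moves: with 4-methoxyphenyl in place of 2-methoxyphenyl, this assay shows an 83-fold lower number from compound 1 to compound 2 (1.92 log units; beyond the scatter); with 2,4-dichlorophenyl in place of 2-methoxyphenyl, it shows a 250-fold lower number from compound 1 to compound 3 (2.40 log units; beyond the scatter); and between the two substituted analogues it shows a 3.0-fold lower number from compound 2 to compound 3 (0.48 log units; beyond the scatter). Compound 4 `CC(=O)Nc1cccc(C2CCN(CCCn3c(-c4ccc(Cl)c(Cl)c4)nc4ccccc43)CC2)c1` differs from compound 1 in that (3,4-dichlorophenyl in place of 2-methoxyphenyl on an aromatic carbon). Both measured departures from 2-methoxyphenyl were large in this assay, and the entering 3,4-dichlorophenyl carries chlorines, as does the group of compound 3, so a large fall is expected for compound 4, estimated at about a 150-fold lower number from compound 1 to compound 4 (2.17 log units; beyond the scatter). Compound 4 is therefore estimated at 5 nM in this assay, with an expected range from 1.5 nM to 20 nM.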

Compound 4, half-maximal inhibitory concentration: 24 nM
Estimate against measurement, compound 4: 4.8-fold (0.68 log units) below, and the stated range ends below it.
By their numbers in this assay, from the lowest: compound 3; then compound 2; then compound 4; then compound 1.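

In this assay, replacing 2-methoxyphenyl with 3,4-dichlorophenyl still gives a 31-fold lower number from compound 1 to compound 4 (1.49 log units; beyond the scatter), but this is the smallest of the three departures from compound 1 seen so far. Carrying two chlorines does not by itself fix the number at this position: moving from one dichlorophenyl pattern to the other gives an 8.0-fold higher number from compound 3 to compound 4 (0.90 log units; beyond the scatter), and 3,4-dichlorophenyl also falls short of 4-methoxyphenyl, with a 2.7-fold higher number from compound 2 to compound 4 (0.43 log units; beyond the scatter). No measurement offered here accounts for these differences.

The compounds shown leave open where unsubstituted phenyl or 4-chlorophenyl would stand, so the contribution of each chlorine in compound 3 and compound 4 cannot be separated. They also leave open how 3-methoxyphenyl would compare with the two methoxyphenyl groups of compound 1 and compound 2.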